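The source may hold more compounds than are shown below. What is called first, only, known or untested is meant among the compounds shown, and "the series" means these compounds.

Measured compounds:
- compound 1 `Oc1ccccc1-c1cncnc1`: 380000 nM
- compound 2 `Oc1ccccc1-c1cccnc1`: 115000 nM

Both compounds were tested in a functional assay on HT-29 cells (Homo sapiens) for cytotoxicity, read by MTT assay, with a stated time of 2 days; a lower number here means a stronger inhibitor, a higher number a weaker inhibitor. Compound 1 gives 380000 nM, the highest number of the two, which makes it the weaker of the pair in this assay. Compound 2 gives 115000 nM, a lower number, and the gap between the two lies beyond the usual scatter, so compound 2 counts as the stronger inhibitor here. Both numbers are very high, so neither compound is a potent inhibitor of these cells.

Compound 3 `c1ccc(-c2cncnc2)cc1` is the next compound to be measured in this assay. It differs from compound 1 in one place: hydrogen in place of hydroxy on an aromatic carbon. The shared core stays the same, and only the hydroxy is lost.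

No step of this kind has been measured among these compounds, so the expected size of the step is uncertain. Compound 1 already gives a very high number, and the change is expected to shift it little, most likely toward a somewhat higher number or to none beyond the scatter; this is the step from compound 1 to compound 3 expected as a 1.3-fold higher number from compound 1 to compound 3 (0.12 log units; within the scatter). Compound 3 is therefore estimated at 500000 nM, with a range from 150000 nM to 2000000 nM.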

Compound 3, half-maximal inhibitory concentration: > 400000 nM
Compound 3 gave a limit, no number; the forecaster's own chance of this, stated with the estimate: 40%; the middle value lies beyond the limit too.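

In this assay compound 3 gives > 400000 nM, which is a limit of the assay and not a number. Replacing the hydroxy with hydrogen on this aromatic carbon is a change of an at least 1.0-fold higher number from compound 1 to compound 3 (0.02 log units; that floor lies within the scatter), so the result gives no sign that removing the hydroxy makes the compound a stronger inhibitor, while the real size of the change stays hidden. This floor is all that can be read from compound 3, because its result stops at the limit of the assay and does not reach a true number: the limit of > 400000 nM in this assay, at which 1 of the 3 values shown sits.

The compounds shown leave open whether another group on this aromatic carbon, such as a methoxy, an amine or a carboxylic acid, would bring the number down and so give a clearer picture of what this position can do. Also open, on these data alone, is what the same loss of the hydroxy would do to compound 2, whose lower number in this assay would leave more room for a rise to be read before the limit is reached.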